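Compound 4: an Oxadiazole Replaces the Amide Arm

The source may hold more compounds than are shown below. What is called first, only, known or untested is meant among the compounds shown, and "the series" means these compounds.

Compound 1 `CCN1CC(NC(=O)[C@@H]2CCCN(S(=O)(=O)c3ccc(S(=O)(=O)N(CC)CC)cc3)C2)C1` carries a (1-ethylazetidin-3-yl)carbamoyl group on a saturated ring carbon of the shared core. In a functional assay on MIA PaCa-2 cells (Homo sapiens) for inhibition, read by MTT assay, with a stated time of 3 days (a higher number here means a weaker inhibitor, a lower number a stronger inhibitor), compound 1 reaches only a limit, > 10000 nM. Compound 2 `CCN(CC)S(=O)(=O)c1ccc(S(=O)(=O)N2CCC[C@@H](C(=O)NC3CN(C(=O)OC(C)(C)C)C3)C2)cc1` also returns only a limit in this assay, > 10000 nM. Compound 3 `CCN(CC)S(=O)(=O)c1ccc(S(=O)(=O)N2CCC[C@@H](C(=O)N[C@H]3CCN(C(=O)OC(C)(C)C)C3)C2)cc1` gives a limit in this assay as well, > 10000 nM. The three measured steps, a step that the two limits leave unreadable from compound 1 to compound 2, a step that the two limits leave unreadable from compound 1 to compound 3 and a step that the two limits leave unreadable from compound 2 to compound 3, therefore cannot be sized, a fact summed up by the limit of > 10000 nM in this assay, at which 3 of the 3 values shown sit. Compound 4 `CCN(CC)S(=O)(=O)c1ccc(S(=O)(=O)N2CCC[C@@H](c3nc(C)no3)C2)cc1` differs from compound 1 in one place: 3-methyl-1,2,4-oxadiazol-5-yl in place of (1-ethylazetidin-3-yl)carbamoyl on a saturated ring carbon. Among the compounds with values here, no measured step touches this position, and none of the measured steps is readable, so the data offer no direction for the change in this assay; all that is known is that every measured analogue sits at the limit. Compound 4 is therefore expected to give in this assay a value of about 15000 nM, in a range from 3000 nM to 60000 nM. This expectation corresponds to a step that the limit leaves unreadable from compound 1 to compound 4, with a limit rather than a number the most likely outcome.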

Compound 4, half-maximal inhibitory concentration: > 10000 nM
Compound 4: no number, only a limit (the forecaster's own chance of this, stated with the estimate: 70%); the middle value does not contradict the limit.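

In this assay compound 4 gives only a limit, > 10000 nM, so its step from compound 1, itself known only as a limit, cannot be read. The compounds shown leave open whether any of these changes alters inhibition, and in which direction: the limit of > 10000 nM in this assay, at which 4 of the 4 values shown sit.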